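The source may hold more compounds than are shown below. What is called first, only, known or untested is meant among the compounds shown, and "the series" means these compounds.

Among the compounds with values here, only two compounds sharing one core have been measured in a functional assay on SW-620 cells (Homo sapiens) for cytotoxicity, read by MTT assay, with a stated time of 72 h (a higher number here means a weaker inhibitor, a lower number a stronger inhibitor), so far. Compound 1 (`COc1cccc(/C=C2\CCC/C(=C\c3ccc(Cl)cc3)C2=O)c1OC`) gives 11100 nM, compound 2 (`COc1cccc(/C=C2\CCC/C(=C\c3cc(Cl)cc(Cl)c3)C2=O)c1OC`) gives 5500 nM, and these two values lie within the scatter of each other. Compound 3 (`COc1cccc(/C=C2\CCC/C(=C\c3ccc(O)c(Cl)c3)C2=O)c1OC`) carries 3-chloro-4-hydroxyphenyl in place of 3,5-dichlorophenyl, on a double-bonded chain carbon bound to a double-bonded ring carbon: 3-chloro-4-hydroxyphenyl in place of 3,5-dichlorophenyl on a double-bonded chain carbon bound to a double-bonded ring carbon. Within the data shown here, the only measured step at this place is a 2.0-fold lower number from compound 1 to compound 2 (0.30 log units; within the scatter), and no measured compound has a hydroxy group there. A step beyond the scatter is therefore not expected in this assay, and the expected size is a 1.1-fold lower number from compound 2 to compound 3 (0.04 log units; within the scatter). For compound 3 the estimated value is 5000 nM, with an expected range of 1800 nM to 14000 nM.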

Compound 3, half-maximal inhibitory concentration: 16800 nM
Compound 3: middle estimate off by 3.4-fold (0.53 log units), on the low side, and the stated range ends below it.
By their numbers in this assay, from the lowest: compounds 2, 1 and 3 (each within the scatter of the next, the first and the last beyond it).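

Replacing 3,5-dichlorophenyl with 3-chloro-4-hydroxyphenyl on a double-bonded chain carbon bound to a double-bonded ring carbon gives a 3.1-fold higher number from compound 2 to compound 3 (0.48 log units; beyond the scatter) in this assay, so a change at this position can now exceed the scatter. Replacing 4-chlorophenyl with the same group gives a 1.5-fold higher number from compound 1 to compound 3 (0.18 log units; within the scatter), so the hydroxy-bearing ring is separated from only one of the two chlorinated rings. No available evidence accounts for this difference. Going by these compounds, whether the hydroxy group itself underlies the step remains open, and 3-chloro-4-methoxyphenyl or 3-chloro-4-aminophenyl at this place would help test it.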